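Amide-side chain length on a bicyclic acid core

This account rests on a few compounds, and the source may have more. Where it says the series, first, only, none or still open, it means among the compounds named here.

Measured compounds in an ADME assay on A2780 cells (Homo sapiens) for cytotoxicity, read by MTT assay, with a stated time of 72 h; on this read-out higher numbers stand for weaker inhibition of growth and lower numbers for stronger inhibition of growth:
- compound 1 `CCCNC(=O)C1C(C(=O)O)[C@@H]2CC[C@H]1O2` gives 10000 nM
- compound 2 `O=C(O)C1C(C(=O)Nc2ccccc2)[C@H]2CC[C@@H]1O2` gives 10000 nM
- compound 3 `C/C(=N/Nc1ccccc1)c1ccccc1NC(=O)C1C(C(=O)O)[C@@H]2CC[C@H]1O2` gives 10000 nM

Compound 1 stands level with compounds 2 and 3 on this read-out; its nearest neighbour is compound 2, and even compound 3 is no further off than the scatter allows. Among the measured compounds shown here, the only single-point step among the measured compounds runs from compound 1 to compound 2, no change at the digits printed from compound 1 to compound 2 (within the scatter), phenyl in place of propyl on the amide nitrogen, and it left the number where it was.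

Compound 4 `CCCCCCCCNC(=O)C1C(C(=O)O)[C@@H]2CC[C@H]1O2` is the next member. Relative to compound 1 the change is pentyl in place of hydrogen on a saturated chain carbon, three bonds along the chain from an amide-type nitrogen. For the measured compounds named here, no measured step touches this kind of chain lengthening; the one step available, from compound 1 to compound 2, swapped the amide substituent without moving the number, so the series so far gives no sign that the amide side responds at all. Compound 4 is therefore expected to sit within the scatter of compound 1, a step of no change at the digits printed from compound 1 to compound 4 (within the scatter). The estimate for compound 4 is 10000 nM, with a range from 4000 nM to 25000 nM.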

Compound 4, concentration for 50% growth inhibition: 10000 nM
The estimate for compound 4 equals the measured number at the digits printed; the range from low to high includes it.
By their numbers in this assay, from the lowest: compounds 1, 2, 3 and 4 (each within the scatter of the next).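

In this assay, pentyl in place of hydrogen on a saturated chain carbon, three bonds along the chain from an amide-type nitrogen, gives no change at the digits printed from compound 1 to compound 4 (within the scatter). Among the compounds shown here, the earlier step from the same parent exchanged propyl for phenyl, so this is the first reading on simple chain lengthening, and an added pentyl also leaves the printed number in place. No supporting data bear on why the amide side shows no response in this read-out.

The compounds shown leave open whether a methyl ester in place of the carboxylic acid would move the number in this assay. Also open, going by these compounds, is whether an amine on the chain of compound 4, or a longer chain such as dodecyl, would separate from the others.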